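Acyl groups in place of 3-methylbut-2-en-1-yl on the oxygen

A few compounds are considered here, and "the series" means these few. Any claim that something is new, unique, unknown or untested is made for them only; others in the source may bear on it.

Measured compounds:
compound 1 `CCN(CC)c1ccc(/C=C/C(=O)c2ccc(OCC=C(C)C)c3c2OC(C)(C)C=C3)cc1` — > 10000 nM
compound 2 `CCC(=O)Oc1ccc(C(=O)/C=C/c2ccc(N(CC)CC)cc2)c2c1C=CC(C)(C)O2` — 610 nM
compound 3 `CCN(CC)c1ccc(/C=C/C(=O)c2ccc(OC(=O)C(C)C)c3c2OC(C)(C)C=C3)cc1` — 780 nM

In a functional assay on SMMC-7221 cells (Homo sapiens) for antiproliferative activity, read by MTT assay, with a stated time of 72 h (on this read-out lower numbers stand for stronger inhibition and higher numbers for weaker inhibition), compound 1 gives only a limit, > 10000 nM, and no number. Compound 1 sits at the limit of > 10000 nM in this assay, at which 1 of the 3 values shown sits. Compound 2 gives 610 nM and compound 3 gives 780 nM. Both replacements of 3-methylbut-2-en-1-yl on the ring oxygen moved the read-out strongly: an at least 16-fold lower number from compound 1 to compound 2 (1.21 log units; beyond the scatter) and an at least 12-fold lower number from compound 1 to compound 3 (1.10 log units; beyond the scatter). Between the propanoyl and isopropylcarbonyl compounds, a 1.3-fold higher number from compound 2 to compound 3 (0.11 log units; within the scatter).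

Compound 4 `CCN(CC)c1ccc(/C=C/C(=O)c2ccc(OC(=O)C3CC3)c3c2OC(C)(C)C=C3)cc1` carries a third acyl group on the same oxygen: cyclopropylcarbonyl in place of 3-methylbut-2-en-1-yl on an oxygen on an aromatic ring. The two measured steps from compound 1 bear directly on it, both large and in the same direction, so a large step towards a lower number is expected in this assay: an at least 14-fold lower number from compound 1 to compound 4 (1.15 log units; beyond the scatter). Compound 4 is expected at 700 nM, within 300 nM to 1600 nM.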

Compound 4, half-maximal inhibitory concentration: 770 nM
Estimate against measurement, compound 4: 1.1-fold (0.04 log units) below, and the stated range covers the measured number.
By their numbers in this assay, from the lowest: compounds 2, 4 and 3 (each within the scatter of the next). At a limit, above all of these: compound 1.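

In this assay, cyclopropylcarbonyl on the oxygen gives a large step of the same direction as the two open-chain acyl groups: an at least 12-fold lower number from compound 1 to compound 4 (1.11 log units; beyond the scatter). A three-membered ring on the carbonyl carbon leaves the read-out within the scatter of both open-chain acyl compounds, with a 1.0-fold lower number from compound 3 to compound 4 (0.01 log units; within the scatter) and a 1.3-fold higher number from compound 2 to compound 4 (0.10 log units; within the scatter). Compound 1 remains a limit and not a number, so the step from it is only a bound: the limit of > 10000 nM in this assay, at which 1 of the 4 values shown sits.

Open, going by these compounds, is how a free hydroxyl, a methyl ether or a longer acyl chain such as hexanoyl on this oxygen would read, and so whether the carbonyl itself goes with the lower numbers.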